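Replacing a pyrrolidine amide by dimethylamino on a coumarin core

The source may report more compounds than this note shows. Statements on the series, on what has been measured and on what is new or still open speak of the compounds shown alone.

Measured so far:
- compound 1, `NC(=O)[C@@H]1CCCN1Cc1cc(=O)oc2cc(OCc3ccccc3)ccc12`: 35000 nM
- compound 2, `NC(=O)[C@@H]1CCCN1Cc1cc(=O)oc2cc(OCc3cccc(F)c3)ccc12`: > 100000 nM

For the measured compounds named here, compound 1 is the only one with a number in an assay (strain Wistar) for inhibition of Amine oxidase [flavin-containing] A (Rattus norvegicus); a lower number here means a stronger inhibitor, a higher number a weaker inhibitor; for compound 1 this assay gives 35000 nM. For compound 2 the same assay reports only a limit, > 100000 nM, which is not a number (the limit of > 100000 nM in this assay, at which 1 of the 2 values shown sits). Going by the values given here, the single measured step, an at least 2.8-fold higher number from compound 1 to compound 2 (0.45 log units; beyond the scatter), concerns fluoro in place of hydrogen on an aromatic carbon.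

Compound 3, `CN(C)Cc1cc(=O)oc2cc(OCc3ccccc3)ccc12`, has not yet been measured. It differs from compound 1 as follows: dimethylamino in place of 2-carbamoylpyrrolidin-1-yl on a saturated chain carbon bound to an aromatic carbon. Among the compounds with values here, the step from compound 1 to compound 2 touches a different part of the structure, so no measured step bears on this change. Compound 3 is therefore expected to sit near compound 1, with a wide range, the estimated step being a 1.2-fold lower number from compound 1 to compound 3 (0.07 log units; within the scatter). The estimate for compound 3 in this assay is 30000 nM, between 5000 nM and 150000 nM.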

Compound 3, half-maximal inhibitory concentration: 100000 nM
Compound 3: middle estimate off by 3.3-fold (0.52 log units), on the low side; measured number inside the range.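

The earlier step changed only an aromatic carbon, whereas this result shows that the group on the saturated chain carbon also affects this assay. Exchanging 2-carbamoylpyrrolidin-1-yl for dimethylamino gives a 2.9-fold higher number from compound 1 to compound 3 (0.46 log units; beyond the scatter), so of these two groups the larger one, with its ring, gives the stronger inhibitor, although compound 1 remains weak at 35000 nM. The number for compound 3 also stands level with a limit reported in this assay: the limit of > 100000 nM in this assay, at which 1 of the 3 values shown sits.

The change removes the ring, the carbamoyl group and the stereocentre all at once, so the compounds shown cannot tell which of these matters. A plain pyrrolidin-1-yl group would separate the ring from the carbamoyl group, and the opposite stereocentre at the same carbon would test whether its arrangement counts.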